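This account rests on a few compounds, and the source may have more. Where it says the series, first, only, none or still open, it means among the compounds named here.

Measured in a functional assay on HepG2 cells (Homo sapiens) for inhibition, read by scintillation counting, with a stated time of 2 h; a higher number here means a weaker inhibitor, a lower number a stronger inhibitor:
compound 1 `CCNC(=O)Nc1sc2ccccc2c1C(=O)N1CCN(C2CCN(C(=O)C(C)C)CC2)CC1`: "not determined" (no result reported)
compound 2 `CCNC(=O)Nc1sc2ccccc2c1C(=O)N1CCN(C2CCN(C(=O)OC)CC2)CC1`: "not determined" (no result reported)
compound 3 `CCNC(=O)Nc1sc2ccccc2c1C(=O)N1CCN(C2CCN(C(=O)OCC)CC2)CC1`: 228 nM

Only one of these three entries is an actual number. Compound 3, at 228 nM, is therefore the single reference point, and it cannot be ranked against compound 1 or compound 2, since neither has a result. This leaves the series with an anchor but no trend.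

The next compound is compound 4 `CCNC(=O)Nc1sc2ccccc2c1C(=O)N1CCN(C2CCN(C(=O)OC3CCCC3)CC2)CC1`. It shares the core of compound 3 and differs only in one group, with cyclopentyl in place of ethyl on an oxygen next to a carbonyl group. The new group is clearly larger and brings a ring where the old one had none.

For the measured compounds named here, no measured pair shows what such a swap does in this assay, so the expectation is a cautious one. A modest move towards stronger inhibition seems slightly more likely than a loss, though the change may well stay within the normal scatter, and a real loss cannot be ruled out. The expected change is a 1.4-fold lower number from compound 3 to compound 4 (0.15 log units; within the scatter). The estimate for compound 4 is 160 nM, with an expected range from 45 nM to 550 nM.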

Compound 4, half-maximal inhibitory concentration: 512 nM
Beside the measured number, compound 4's estimate is 3.2-fold (0.51 log units) below it; measured number inside the range.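

In this assay, for the compounds shown here, the first step that can be read is a 2.2-fold higher number from compound 3 to compound 4 (0.35 log units; beyond the scatter) and it comes with cyclopentyl in place of ethyl on an oxygen next to a carbonyl group, which shows that the number responds to what sits at this place. The step is modest but beyond the usual scatter, and compound 4 still gives a measured value, so going from two heavy atoms and no ring to five heavy atoms in a ring weakens inhibition here without removing it. Nothing measured in this set explains why the number rises.

The steps involving compound 1 and compound 2 cannot be read, and this single step cannot separate the effect of the ring from that of the added carbons. From the compounds shown here alone, whether an open butyl chain would give a similar number to cyclopentyl, and where a smaller ring such as cyclopropyl would fall between ethyl and cyclopentyl, if it falls there at all, remain open questions.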